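Adding a Sulfur to a Trifluoromethyl Group

The source may report more compounds than this note shows. Statements on the series, on what has been measured and on what is new or still open speak of the compounds shown alone.

Measured compounds:
compound 1 `N#Cc1cccc(NC(=O)C(Cl)Cl)c1` 60900 nM
compound 2 `O=C(Nc1cccc(C(F)(F)F)c1)C(Cl)Cl` 8860 nM

Going by the values given here, in a functional assay on KB cells (Homo sapiens) for antiproliferative activity, read by MTT assay, with a stated time of 72 h (on this read-out higher numbers stand for weaker inhibition and lower numbers for stronger inhibition), compound 2 gives 8860 nM and holds the lowest of the two numbers; the only other compound, compound 1, sits higher by a 6.9-fold lower number from compound 1 to compound 2 (0.84 log units; beyond the scatter). Compound 3 `O=C(Nc1cccc(SC(F)(F)F)c1)C(Cl)Cl` differs from compound 2 by (trifluoromethyl)sulfanyl in place of trifluoromethyl on an aromatic carbon. Among the compounds with values here, no measured step matches this change; the single known step concerns a different group and gives no guide. Compound 3 is therefore expected to differ from compound 2 only slightly, within the scatter, by a 1.5-fold lower number from compound 2 to compound 3 (0.17 log units; within the scatter). Compound 3 is estimated at 6000 nM, in the range 2000 nM to 20000 nM.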

Compound 3, half-maximal inhibitory concentration: 4840 nM
The estimate for compound 3 lay 1.2-fold (0.09 log units) above the measured number; the range from low to high includes it.
By their numbers in this assay, from the lowest: compounds 3 and 2 (each within the scatter of the next); then compound 1.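

Putting (trifluoromethyl)sulfanyl in place of trifluoromethyl gives a 1.8-fold lower number from compound 2 to compound 3 (0.26 log units; within the scatter), so at this position the added sulfur brings no clear change. Putting the same group in place of cyano gives a 13-fold lower number from compound 1 to compound 3 (1.10 log units; beyond the scatter), a larger step than the one cyano to trifluoromethyl had shown, and compound 1 stays apart from the two fluorine-bearing compounds. Nothing measured here accounts for these differences.

The compounds shown leave open how an amine or a carboxylic acid on this aromatic carbon would read. They also leave open whether a longer fluorinated chain on the sulfur would move the number beyond the scatter.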